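A few compounds are considered here, and "the series" means these few. Any claim that something is new, unique, unknown or untested is made for them only; others in the source may bear on it.

Measured so far:
compound 1 (`CNC(=O)c1cc(C(=O)N[C@@H]2C[C@H]2CO)cc2c1O[C@H](CF)[C@H]2c1ccccc1`) gives 0.5 h
compound 2 (`CNC(=O)c1cc(C(=O)NC2CC2)cc2c1O[C@H](CO)[C@H]2c1ccccc1`) gives 0.4 h

In an ADME assay on the whole organism (Rattus norvegicus, strain Wistar Han) for metabolic stability, read by LC-MS, with stated times of 1 h and 7 h, at a dose of 1 mg/kg by the intravenous route (a lower number here means that the compound disappears faster, a higher number that the compound lasts longer), only these two compounds are available, and compound 1 (0.5 h) cannot be separated from compound 2 (0.4 h), since the two values lie within the scatter of each other. Within the data shown here, the pair differs in more than one place, so it gives no single-change step to calibrate against.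

The next compound, compound 3 (`CNC(=O)c1cc(C(=O)NCCC[C@H]2OC[C@H](N)CO2)cc2c1O[C@H](CF)[C@H]2c1ccccc1`), keeps the core of compound 1 and changes only the group on an amide-type nitrogen. The counted difference is a group of 10 heavy atoms (7 carbon, 1 nitrogen, 2 oxygen; one six-membered non-aromatic ring with 2 hetero atoms) in place of a group of 5 heavy atoms (4 carbon, 1 oxygen; one three-membered non-aromatic ring of carbon only), on an amide-type nitrogen. The incoming group brings a six-membered non-aromatic ring with 2 hetero atoms where the three-membered ring of carbon only stood.

Among the measured compounds shown here, no measured pair covers this change, so the expectation rests on judgement and is weakly anchored. A small upward move in this assay is expected, not clearly beyond the scatter, and the estimate is a 1.8-fold higher number from compound 1 to compound 3 (0.26 log units; within the scatter). The range is kept wide on the upper side. Compound 3 is estimated at 0.9 h, with an expected range from 0.4 h to 2.5 h.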

Compound 3, half-life: 0.6 h
Compound 3: the middle estimate sits 1.5-fold (0.18 log units) above what was measured; the range from low to high includes it.
By their numbers in this assay, from the lowest: compounds 2, 1 and 3 (each within the scatter of the next).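

Among these compounds, the first single-place step sits on an amide-type nitrogen: in this assay, a group of 10 heavy atoms (7 carbon, 1 nitrogen, 2 oxygen; one six-membered non-aromatic ring with 2 hetero atoms) in place of a group of 5 heavy atoms (4 carbon, 1 oxygen; one three-membered non-aromatic ring of carbon only) gives a 1.2-fold higher number from compound 1 to compound 3 (0.08 log units; within the scatter) and so stays within the scatter. On this single pair, the half-life at this position does not separate the two groups, even though the incoming group has the higher count of heavy atoms and of hydrogen-bond acceptors. Nothing measured here speaks to the reason for this result.

On these data alone, whether this holds for other groups on the same amide-type nitrogen remains open, for example a carboxylic acid or a plain methyl group. Among the compounds shown here, the fluoromethyl and hydroxymethyl groups also remain unresolved, as no single-place step isolates them on the shared core.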